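This account rests on a few compounds, and the source may have more. Where it says the series, first, only, none or still open, it means among the compounds named here.

Measured in a functional assay on MCF7 cells (Homo sapiens) for inhibition, with a stated time of 48 h; on this read-out higher numbers stand for weaker inhibition and lower numbers for stronger inhibition:
- compound 1 `COc1cc(Sc2c[nH]c3ccc(N)cc23)cc(OC)c1OC`: 260 nM
- compound 2 `COc1cc(Sc2c[nH]c3ccc(C)cc23)cc(OC)c1OC`: 16 nM
- compound 3 `COc1ccc2[nH]cc(Sc3cc(OC)c(OC)c(OC)c3)c2c1`: 22 nM

Compound 3 stands with compound 2 and well clear of compound 1 on these numbers. The next structure is compound 4 `COc1cc(Sc2c[nH]c3ccc(OCCOCc4ccccc4)cc23)cc(OC)c1OC`, which turns methoxy into 2-(benzyloxy)ethoxy: (benzyloxy)methyl in place of hydrogen on a saturated chain carbon bound to an oxygen on an aromatic ring. Among the compounds with values here, two measured steps bear on this. The first, a 1.4-fold higher number from compound 2 to compound 3 (0.14 log units; within the scatter), involves only small groups on an aromatic carbon. The second, a 12-fold lower number from compound 1 to compound 3 (1.07 log units; beyond the scatter), shows that a change on an aromatic carbon can be large. Neither tests a chain of this length, so the size remains uncertain, but a moderate rise towards weaker inhibition is expected. The expected change is a 5.5-fold higher number from compound 3 to compound 4 (0.74 log units; beyond the scatter). The estimated value for compound 4 is 120 nM, with an expected range of 25 nM to 600 nM.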

Compound 4, half-maximal inhibitory concentration: 260 nM
Estimate against measurement, compound 4: 2.2-fold (0.34 log units) below, within the range that was stated.
By their numbers in this assay, from the lowest: compounds 2 and 3 (each within the scatter of the next); then compounds 1 and 4 (each within the scatter of the next).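

In this assay, methyl and methoxy on this aromatic carbon sit within the scatter of each other, but the longer 2-(benzyloxy)ethoxy group does not hold that level (a 12-fold higher number from compound 3 to compound 4 (1.07 log units; beyond the scatter); a 16-fold higher number from compound 2 to compound 4 (1.21 log units; beyond the scatter)). This chain instead matches the amino group of compound 1 (no change at the digits printed from compound 1 to compound 4 (within the scatter)), so this position is not indifferent to what is placed on the oxygen. No measured data explain the rise.

Open, from the compounds shown here alone, is whether the rise follows chain length or the terminal benzyl group. A 2-methoxyethoxy or 2-hydroxyethoxy group at this position would separate the two.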